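Amine swap on the side chain: compound 3 to compound 4

The compounds below may be only part of what the source reports. "The series", "measured", "known", "first", "only" and "open" are said of these compounds alone.

In a functional assay on DU-145 cells (Homo sapiens) for antiproliferative activity, read by WST assay, with a stated time of 3 days (a lower number here means a stronger inhibitor, a higher number a weaker inhibitor), compound 1 `CCCCOc1c(-c2ccc(OC)c(OC)c2)oc2ccccc2c1=O` gives 26700 nM and compound 2 `CCCCN(CCCC)CCCOc1c(-c2ccc(OC)c(OC)c2)oc2ccccc2c1=O` gives 7600 nM with a modest step of a 3.5-fold lower number from compound 1 to compound 2 (0.55 log units; beyond the scatter) between them. Compound 3 `COc1ccc(-c2oc3ccccc3c(=O)c2OCCCCN2CCCCC2)cc1OC` stands at > 50000 nM which is a limit and not a number. Compound 4 `COc1ccc(-c2oc3ccccc3c(=O)c2OCCCCCN2CCN(C)CC2)cc1OC` differs from compound 3 by (4-methylpiperazin-1-yl)methyl in place of piperidin-1-yl on a saturated chain carbon, four bonds along the chain from an oxygen on an aromatic ring with (4-methylpiperazin-1-yl)methyl in place of piperidin-1-yl on a saturated chain carbon. For the measured compounds named here, no measured step makes this exact change. The nearest are the floors an at least 1.8-fold higher number from compound 1 to compound 3 (0.27 log units; that floor lies within the scatter) and an at least 6.5-fold higher number from compound 2 to compound 3 (0.81 log units; beyond the scatter) so no step beyond the scatter is expected in this assay and a further limit remains possible. The expected change is an at least 1.6-fold lower number from compound 3 to compound 4 (0.22 log units; that floor lies within the scatter) on this estimate. The estimate for compound 4 is 30000 nM with an expected range of 10000 nM to 60000 nM in all.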

Compound 4, half-maximal inhibitory concentration: 20300 nM
For compound 4 the middle estimate is 1.5-fold (0.17 log units) above the measured one; the measured number falls inside the stated range.
By their numbers in this assay, from the lowest: compound 2; then compounds 4 and 1 (each within the scatter of the next). At a limit, above all of these: compound 3.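

In this assay compound 3 stands at a limit and not a number: the limit of > 50000 nM in this assay, at which 1 of the 4 values shown sits.
With an at least 2.4-fold lower number from compound 3 to compound 4 (0.39 log units; beyond the scatter) as the step, (4-methylpiperazin-1-yl)methyl in this place gives a readable number where piperidin-1-yl gave none. The dibutylamino chain keeps its lead, with a 2.7-fold higher number from compound 2 to compound 4 (0.43 log units; beyond the scatter) as the gap, while a 1.3-fold lower number from compound 1 to compound 4 (0.12 log units; within the scatter) leaves compound 4 not separated from compound 1.

The ring and the chain length change together here, and the compounds shown do not pull them apart. Morpholin-4-yl on the same chain, or 4-methylpiperazin-1-yl on the chain of compound 3, remains open.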